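Loss of the phenolic hydroxy in the aryl series

A few compounds are considered here, and "the series" means these few. Any claim that something is new, unique, unknown or untested is made for them only; others in the source may bear on it.

Among the measured compounds shown here, compound 1 `CCC1=C(O)c2c(oc(-c3ccc(O)cc3)cc2=O)C(CC)(CC)C1=O` is the only member with a full number: in a functional assay on KB cells (Homo sapiens) for antiproliferative activity, read by sulforhodamine B assay, with a stated time of 3 days (a lower number here means that less compound is needed, a higher number that more compound is needed for the effect), compound 1 gives 20.6 uM. Compound 2 `CCC1=C(O)c2c(oc(-c3ccc(SC)cc3)cc2=O)C(CC)(CC)C1=O` reaches only a limit of the assay in this assay, > 52.1 uM, which is the limit of > 52.1 uM in this assay, at which 1 of the 2 values shown sits. For the measured compounds named here, the single measured step, an at least 2.5-fold higher number from compound 1 to compound 2 (0.40 log units; beyond the scatter), also removes the hydroxy. Compound 3 `CCC1=C(O)c2c(oc(-c3ccccc3OC)cc2=O)C(CC)(CC)C1=O` differs from compound 1 by 2-methoxyphenyl in place of 4-hydroxyphenyl on an aromatic carbon, so the hydroxy is again gone. Compound 3 is therefore expected to move to a higher number, a 2.2-fold higher number from compound 1 to compound 3 (0.34 log units; beyond the scatter). The estimate for compound 3 is 45 uM, within a range from 20 uM to 100 uM, and a limit rather than a number is quite possible.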

Compound 3, concentration for half-maximal effect: 40.8 uM
Compound 3: the middle estimate sits 1.1-fold (0.04 log units) above what was measured; measured number inside the range.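

Loss of the hydroxy does not by itself move the number beyond the scatter: in this assay, the change to 2-methoxyphenyl gives a 2.0-fold higher number from compound 1 to compound 3 (0.30 log units; within the scatter). The earlier step therefore cannot be tied to that loss alone. The two aryl groups without a hydroxy are not yet separated, with an at least 1.2-fold lower number from compound 2 to compound 3 (0.10 log units; that floor lies within the scatter), and that step rests on a limit rather than a number: the limit of > 52.1 uM in this assay, at which 1 of the 3 values shown sits.

Still open, from the compounds shown here alone, is whether the methoxy group or its ring position matters, a question 4-methoxyphenyl would address. Going by these compounds, how an amine or a carboxylic acid on the same ring would read also remains open.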